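The compounds below may be only part of what the source reports. "The series", "measured", "known", "first", "only" and "open" are said of these compounds alone.

Measured in a functional assay on A-375 cells (Homo sapiens) for antiproliferative activity, read by MTT assay, with a stated time of 24 h; on this read-out lower numbers stand for stronger inhibition and higher numbers for weaker inhibition:

- compound 1 `C=CCOc1ccc2c(=O)c(-c3cc(OC)c(OC)cc3OC)coc2c1`: 4750 nM
- compound 2 `COc1cc(OC)c(-c2coc3cc(OCc4ccccc4)ccc3c2=O)cc1OC`: 1640 nM
- compound 3 `COc1cccc(C(=O)Oc2ccc3c(=O)c(-c4cc(OC)c(OC)cc4OC)coc3c2)c1`: > 10000 nM, a limit of the assay and not a number

Compound 3 is the weakest of the three, with only a limit to its name: the limit of > 10000 nM in this assay, at which 1 of the 3 values shown sits. The two steps that reach it are an at least 2.1-fold higher number from compound 1 to compound 3 (0.32 log units; beyond the scatter) and an at least 6.0-fold higher number from compound 2 to compound 3 (0.78 log units; beyond the scatter).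

The next compound, compound 4 `COc1cc(OC)c(-c2coc3cc(OCc4ccccc4F)ccc3c2=O)cc1OC`, changes one place: 2-fluorobenzyl in place of (3-methoxyphenyl)carbonyl on an oxygen on an aromatic ring. In words, 2-fluorobenzyl stands in place of (3-methoxyphenyl)carbonyl on an oxygen on an aromatic ring.

The most relevant measurement is the second step above, read backwards, since compound 2 carries benzyl on that same oxygen. The benzyl group also gave a gain over allyl, seen in a 2.9-fold lower number from compound 1 to compound 2 (0.46 log units; beyond the scatter). Among the compounds with values here, no fluorinated compound has been measured, so the effect of the fluorine remains open. A clear move to a lower number is therefore expected, and the expected step is an at least 5.8-fold lower number from compound 3 to compound 4 (0.76 log units; beyond the scatter). The estimate for compound 4 is 1700 nM, with an expected range from 650 nM to 4800 nM.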

Compound 4, half-maximal inhibitory concentration: 2100 nM
Estimate against measurement, compound 4: 1.2-fold (0.09 log units) below, and the stated range covers the measured number.
By their numbers in this assay, from the lowest: compounds 2 and 4 (each within the scatter of the next); then compound 1. At a limit, above all of these: compound 3.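

In this assay, the first fluorine on the benzyl ring leaves the reading unresolved from its parent, fluoro in place of hydrogen on an aromatic carbon giving only a difference within the scatter (a 1.3-fold higher number from compound 2 to compound 4 (0.11 log units; within the scatter)). The 2-fluorobenzyl group keeps the advantage that benzyl showed on this oxygen, both against allyl (a 2.3-fold lower number from compound 1 to compound 4 (0.35 log units; beyond the scatter)) and against (3-methoxyphenyl)carbonyl (an at least 4.7-fold lower number from compound 3 to compound 4 (0.67 log units; beyond the scatter)). That last step has no exact size, as compound 3 has only a limit of the assay and not a number: the limit of > 10000 nM in this assay, at which 1 of the 4 values shown sits.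

The compounds shown leave open whether fluoro elsewhere on the benzyl ring would read the same in this assay. Also open, on these data alone, is how a plain benzoyl group, an amine or a longer chain on this oxygen would compare.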